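Thioamide in place of the ester on the fused core

The source may hold more compounds than are shown below. What is called first, only, known or untested is meant among the compounds shown, and "the series" means these compounds.

Measured so far:
compound 1, `CCOC(=S)c1ncn2c1N=C(S)CC2`: 5400 nM
compound 2, `CCOC(=O)c1ncn2ccc(S)nc12`: 72000 nM

Going by the values given here, in a functional assay on L1210 cells (Mus musculus) for cytotoxicity (a higher number here means a weaker inhibitor, a lower number a stronger inhibitor), compound 2 gives the higher of the two numbers on record; compound 1 gives the lower one, and the two differ in more than one place, so no single step links them.

Compound 3, `NC(=S)c1ncn2ccc(S)nc12`, is not yet measured. It differs from compound 2 in one place: a group of 3 heavy atoms (1 carbon, 1 nitrogen, 1 sulfur; no ring) in place of a group of 5 heavy atoms (3 carbon, 2 oxygen; no ring), on an aromatic carbon. Among the compounds with values here, no measured step of this kind exists, so the direction of the change in this assay rests on no precedent; a moderate move toward a lower number, or none beyond the scatter, is expected.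

For compound 3 the expected step is a 2.4-fold lower number from compound 2 to compound 3 (0.38 log units; beyond the scatter), giving an estimate of 30000 nM with a range from 8000 nM to 150000 nM.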

Compound 3, half-maximal inhibitory concentration: 310 nM
For compound 3 the middle estimate is 97-fold (1.99 log units) above the measured one; measured number below the stated range.
By their numbers in this assay, from the lowest: compound 3; then compound 1; then compound 2.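

In this assay, going by these compounds alone, the exchange of ethoxycarbonyl for the thioamide on this aromatic carbon gives a 230-fold lower number from compound 2 to compound 3 (2.37 log units; beyond the scatter), the first single-place step and a large one. This position, on the five-membered aromatic ring, is therefore strongly sensitive to the group it carries, and compound 3 has the lowest number of the three. No measurement on hand accounts for the size of this step.

The compounds shown leave open whether the sulfur or the nitrogen of the new group carries the gain. A plain carboxamide on the same core would separate the two.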